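This account rests on a few compounds, and the source may have more. Where it says the series, first, only, none or still open, it means among the compounds named here.

Compound 1 `NC(C(=O)NCC(=O)Nc1ccc(Cl)cc1C(=O)c1ccccc1)c1ccccc1` is the weaker of the two measured compounds in a functional assay on the whole organism for antagonist activity, with Mus musculus as the target; on this read-out lower numbers stand for an effect already at smaller amounts and higher numbers for an effect only at larger amounts of compound: compound 1 needs 28 mg/kg, while compound 2 `CC(NC(=O)CN)C(=O)N(C)c1ccc(Cl)cc1C(=O)c1ccccc1Cl` reaches the same effect at 0.47 mg/kg, a gap well beyond the usual scatter of this assay. Compound 2 differs from compound 1 in several places at once, so the two values together do not show which change carries that gap.

Compound 3 `CC(=O)NCC(=O)Nc1ccc(Cl)cc1C(=O)c1ccccc1` changes compound 1 in a single place: methyl in place of amino(phenyl)methyl on a carbonyl carbon. For the measured compounds named here, no pair of measured compounds shows this change on its own, so nothing here says how large its effect tends to be or in which direction it runs. The change strips a ring and both a donor and an acceptor from the side chain, and the expected outcome is a somewhat higher dose, with the step from a 1.8-fold higher number from compound 1 to compound 3 (0.25 log units; within the scatter) counted as a modest loss. Compound 3 is accordingly expected to give about 50 mg/kg, most likely between 10 mg/kg and 250 mg/kg.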

Compound 3, dose for half-maximal effect: 37 mg/kg
Compound 3: the middle estimate sits 1.4-fold (0.13 log units) above what was measured, and the stated range covers the measured number.
By their numbers in this assay, from the lowest: compound 2; then compounds 1 and 3 (each within the scatter of the next).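

In this assay, putting methyl in place of amino(phenyl)methyl on a carbonyl carbon gives a 1.3-fold higher number from compound 1 to compound 3 (0.12 log units; within the scatter) and so leaves the dose indistinguishable. For the compounds shown here, this is the first single-place comparison, and it shows that the whole amino(phenyl)methyl group, aromatic ring included, can be exchanged for methyl at this position without a change that stands out from the scatter. No measured information on either group bears on this result, so the outcome stays an observation without an explanation.

Going by these compounds, it remains open whether other groups on this carbonyl carbon, such as an aminomethyl group, a longer propyl chain or a carboxylic acid, would also leave the dose unchanged. One pair also cannot show whether the same exchange would do as little on a different core.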